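Oxolanyl chain to 4-fluorobenzyl: solubility working notes

This account rests on a few compounds, and the source may have more. Where it says the series, first, only, none or still open, it means among the compounds named here.

Compound 1 `O=C(O)C[C@H]1CC[C@H](c2ccc(C(=O)Nc3nnc(CCC4CCCO4)s3)cc2)CC1`: 90000 nM
Compound 2 `O=C(O)C[C@H]1CC[C@H](c2ccc(C(=O)Nc3nnc(CCC4CCOC4)s3)cc2)CC1`: 95000 nM

In a physicochemical assay for solubility, read by HPLC, in phosphate buffer, with a stated time of 20 h, at pH 7.4 (on this read-out lower numbers stand for lower solubility and higher numbers for higher solubility), compound 2 gives 95000 nM, which is within the scatter of compound 1. Among the compounds with values here, only one measured step exists so far: a 1.1-fold higher number from compound 1 to compound 2 (0.02 log units; within the scatter). It exchanges oxolan-2-yl for oxolan-3-yl and stays within the scatter.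

Next comes compound 3 `O=C(O)C[C@H]1CC[C@H](c2ccc(C(=O)Nc3nnc(Cc4ccc(F)cc4)s3)cc2)CC1`, which carries 4-fluorophenyl in place of (oxolan-3-yl)methyl on a saturated chain carbon bound to an aromatic carbon. Cut one bond further out, the same difference reads 2-(oxolan-3-yl)ethyl to 4-fluorobenzyl.

This change is of another kind than the measured one. The five-membered non-aromatic ring leaves, and a six-membered aromatic ring of carbon only enters. Within the data shown here, no measured compound carries such a ring at this place, so the single step bears on it only weakly and the range stays wide. A lower number beyond the scatter is expected, though its size is poorly fixed. The estimated step is a 3.8-fold lower number from compound 2 to compound 3 (0.58 log units; beyond the scatter). For compound 3 the expected value is 25000 nM, with an estimated range of 4000 nM to 100000 nM.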

Compound 3, solubility: < 2000 nM
Compound 3: only a limit was reported; the forecaster's own chance of this, stated with the estimate: 5%; middle value at least 12-fold (1.09 log units) from the limit.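

Compound 3 is reported in this assay only as a limit of the assay, not as a number: the limit of < 2000 nM in this assay, at which 1 of the 3 values shown sits. Until now this position had shown only the exchange of oxolan-2-yl for oxolan-3-yl, with a 1.1-fold higher number from compound 1 to compound 2 (0.02 log units; within the scatter), whereas 4-fluorophenyl in place of (oxolan-3-yl)methyl on a saturated chain carbon bound to an aromatic carbon gives an at least 47-fold lower number from compound 2 to compound 3 (1.67 log units; beyond the scatter), and 4-fluorophenyl in place of (oxolan-2-yl)methyl at the same place gives an at least 45-fold lower number from compound 1 to compound 3 (1.65 log units; beyond the scatter). The read-out at this position therefore does change with what is attached there, and the large step appears from either oxolanyl chain, so the position is not indifferent to every change.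

The change to 4-fluorobenzyl replaces the non-aromatic ring with an aromatic one, removes the ring oxygen, adds the fluorine and alters the chain all at once, so the compounds shown do not assign the step to any one of these parts. Plain benzyl, 2-(4-fluorophenyl)ethyl and cyclopentylmethyl at this place would separate those parts, and a chain ending in an amine remains an open comparison.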